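The source may report more compounds than this note shows. Statements on the series, on what has been measured and on what is new or still open speak of the compounds shown alone.

Compound 3 `COc1cc(/C=C/C(=O)OCCCO[N+](=O)[O-])ccc1O` sits at the weak end of the three esters measured so far. In a functional assay on A549 cells (Homo sapiens) for cytotoxicity, read by resazurin assay, with a stated time of 72 h (a higher number here means a weaker inhibitor, a lower number a stronger inhibitor), compound 3 gives 13200 nM, the highest of the three numbers. Compound 1 `COc1cc(/C=C/C(=O)OC/C=C/CO[N+](=O)[O-])ccc1O` gives 5950 nM in this assay, and compound 2 `COc1cc(/C=C/C(=O)OCCCCCO[N+](=O)[O-])ccc1O` gives 6390 nM. The two steps that reach compound 3 both point the same way: a 2.2-fold higher number from compound 1 to compound 3 (0.35 log units; beyond the scatter), and a 2.1-fold higher number from compound 2 to compound 3 (0.32 log units; beyond the scatter). In each, a shorter chain carrying the nitrooxy group went with a weaker inhibitor.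

Compound 4 `COc1cc(/C=C/C(=O)OC(C)C)ccc1O` takes the change one step further. isopropyl in place of 3-(nitrooxy)propyl on an oxygen next to a carbonyl group The nitrooxy group, together with the chain that carried it, is gone. Going by the values given here, no measured pair shows the loss of the nitrooxy group by itself, so the two steps above are the nearest guide; both were modest, beyond the scatter, and in the direction of a higher number as the chain shrank. A further, somewhat larger rise toward a higher number is therefore expected for compound 4, as a 2.3-fold higher number from compound 3 to compound 4 (0.36 log units; beyond the scatter). In this assay compound 4 is expected to give 30000 nM, with a plausible range from 10000 nM to 100000 nM.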

Compound 4, half-maximal inhibitory concentration: > 50000 nM
Compound 4 was reported as a limit (the forecaster's own chance of this, stated with the estimate: 30%); at least 1.6-fold (0.22 log units) between middle value and limit.
By their numbers in this assay, from the lowest: compounds 1 and 2 (each within the scatter of the next); then compound 3. At a limit, above all of these: compound 4.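

Going by these compounds alone, putting isopropyl in place of 3-(nitrooxy)propyl on an oxygen next to a carbonyl group gives an at least 3.7-fold higher number from compound 3 to compound 4 (0.57 log units; beyond the scatter), and this is the first step here in which the nitrooxy group leaves along with its chain. Compound 4 is reported only as a limit in this assay: the limit of > 50000 nM in this assay, at which 1 of the 4 values shown sits. The earlier steps shown here all kept the nitrooxy group and changed only the chain that carried it, so this step alone shows that, at this position, an ester with no nitrooxy group lies on the weak side of compound 3, by a margin beyond the scatter.

The change removes the nitrooxy group and reshapes the chain in a single step, so the compounds shown cannot say how much of the rise belongs to either, and a plain propyl ester or a 3-hydroxypropyl ester would separate the two. They also leave open whether the nitrooxy group could be replaced by another end group on the same chain, such as an amine or a carboxylic acid, and how such a chain would compare with compound 3 in this assay.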